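A few compounds are considered here, and "the series" means these few. Any claim that something is new, unique, unknown or untested is made for them only; others in the source may bear on it.

For the measured compounds named here, in a functional assay on the whole organism with Rattus norvegicus as the target (a higher number here means that more compound is needed for the effect, a lower number that less compound is needed), compound 1 `CCOCCOC(=O)C(=O)Nc1nc(-c2cc(-c3ccccc3)on2)cs1` gives 0.2 mg/kg, the lowest of the two numbers measured so far. Compound 2 `CCOCCOC(=O)C(=O)Nc1nc(-c2cc(CO)on2)cs1` has hydroxymethyl in place of phenyl on an aromatic carbon and gives 1.8 mg/kg. Compound 3 `O=C(O)C(=O)Nc1nc(-c2cc(-c3ccccc3)on2)cs1` keeps the phenyl of compound 1 and differs at the other end of the molecule: hydrogen in place of 2-ethoxyethyl on an oxygen next to a carbonyl group. Hydrogen stands in place of 2-ethoxyethyl on an oxygen next to a carbonyl group, which turns the (2-ethoxyethoxy)carbonyl into a carboxy.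

Going by the values given here, no measured step touches this place. Among the compounds with values here, the only step available is a 9.0-fold higher number from compound 1 to compound 2 (0.95 log units; beyond the scatter), and it lies elsewhere on the molecule, so it offers only a rough gauge of how far a single change has moved the numbers in this assay here. A modest move towards a higher number seems the likeliest outcome, smaller than that gauge, though the data do not exclude a move the other way. The expected step is a 2.5-fold higher number from compound 1 to compound 3 (0.40 log units; beyond the scatter). Compound 3 is estimated at 0.5 mg/kg, with an expected range from 0.08 mg/kg to 3 mg/kg.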

Compound 3, dose for half-maximal effect: 0.23 mg/kg
For compound 3 the middle estimate is 2.2-fold (0.34 log units) above the measured one, and the stated range covers the measured number.
By their numbers in this assay, from the lowest: compounds 1 and 3 (each within the scatter of the next); then compound 2.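

Here this assay gives the first reading at this end of the molecule: hydrogen in place of 2-ethoxyethyl, which turns the (2-ethoxyethoxy)carbonyl into a carboxy, gives a 1.2-fold higher number from compound 1 to compound 3 (0.06 log units; within the scatter). For the compounds shown here, with the phenyl in place, therefore, the whole 2-ethoxyethyl chain can be exchanged for hydrogen without a change beyond the scatter, whereas the single change at the other end, hydroxymethyl in place of phenyl, gives a 9.0-fold higher number from compound 1 to compound 2 (0.95 log units; beyond the scatter). Nothing available explains why this end of the molecule shows so little response to the exchange.

The compounds shown leave open whether a small group on this oxygen, such as methyl or ethyl, or a longer chain than 2-ethoxyethyl, would also stay within the scatter, and whether an amine on the same carbonyl, giving an amide in place of the carboxy, would do so too. They also leave open whether the carboxy end would tolerate hydroxymethyl in place of phenyl, since the step to hydroxymethyl is known only with the 2-ethoxyethyl chain present.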